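A few compounds are considered here, and "the series" means these few. Any claim that something is new, unique, unknown or untested is made for them only; others in the source may bear on it.

Series notes. For the measured compounds named here, in a functional assay on CAPAN-1 cells (Homo sapiens) for antiproliferative activity, with a stated time of 72 h (on this read-out higher numbers stand for weaker inhibition and lower numbers for stronger inhibition), compound 1 `Nc1ncnn2c([C@@H]3O[C@H](CO)[C@@H](O)[C@H]3O)cc(C#Cc3ccc(F)cc3)c12` gives 55400 nM, the second highest of the three numbers so far. Compound 2 `Nc1ncnn2c([C@@H]3O[C@H](CO)[C@@H](O)[C@H]3O)cc(-c3ccccc3)c12` gives 65200 nM and compound 3 `COc1ccc(-c2cc([C@@H]3O[C@H](CO)[C@@H](O)[C@H]3O)n3ncnc(N)c23)cc1` gives 43900 nM; the gaps, a 1.2-fold higher number from compound 1 to compound 2 (0.07 log units; within the scatter) and a 1.3-fold lower number from compound 1 to compound 3 (0.10 log units; within the scatter), sit within the scatter, as does a 1.5-fold lower number from compound 2 to compound 3 (0.17 log units; within the scatter). Compound 4 `Cc1ccccc1-c1cc([C@@H]2O[C@H](CO)[C@@H](O)[C@H]2O)n2ncnc(N)c12` differs from compound 1 in one place: 2-methylphenyl in place of 2-(4-fluorophenyl)ethynyl on an aromatic carbon. The two measured swaps from compound 1 to a directly attached aryl group bear on this step, and neither moved the number beyond the scatter, so no step beyond the scatter is expected here either. The step expected for compound 4 is a 1.0-fold lower number from compound 1 to compound 4 (0.00 log units; within the scatter). For compound 4 the estimate is 55000 nM, with a range from 25000 nM to 120000 nM.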

Compound 4, half-maximal inhibitory concentration: 97500 nM
For compound 4 the middle estimate is 1.8-fold (0.25 log units) below the measured one, within the range that was stated.
By their numbers in this assay, from the lowest: compounds 3, 1, 2 and 4 (each within the scatter of the next, the first and the last beyond it).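

At this aromatic carbon, 2-methylphenyl stays within the scatter of 2-(4-fluorophenyl)ethynyl (a 1.8-fold higher number from compound 1 to compound 4 (0.25 log units; within the scatter)), and adding methyl to the phenyl group of compound 2 also stays within it (a 1.5-fold higher number from compound 2 to compound 4 (0.17 log units; within the scatter)). In this assay, for the compounds shown here, the first step beyond the scatter is a modest one, between two directly attached aryl groups (a 2.2-fold higher number from compound 3 to compound 4 (0.35 log units; beyond the scatter)). No measurement shown accounts for this step.

Going by these compounds, whether an amine, a carboxylic acid or a longer alkyl chain at this carbon would give a larger step remains open.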